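Dropping the Carbamoyl Group: Expected Effect on Growth Inhibition

The compounds below may be only part of what the source reports. "The series", "measured", "known", "first", "only" and "open" are said of these compounds alone.

Compound 1 `CC[C@@H]1C(=O)N(C)c2cnc(Nc3ccc(S(N)(=O)=O)cc3)nc2N1C1CCCC1`: 5290 nM
Compound 2 `CCC1C(=O)N(C)c2cnc(Nc3ccc(S(=O)(=O)NCC(C)C)cc3)nc2N1c1ccn(C)n1`: 15000 nM
Compound 3 `CC[C@@H]1C(=O)N(C)c2cnc(-n3ccc4cc(C(=O)NC(C)C)ccc43)nc2N1C1CCCC1`: 1840 nM

All three compounds were tested in a functional assay on NCI-H1975 cells (Homo sapiens) for antiproliferative activity, read by CCK-8 assay, with a stated time of 72 h; a lower number here means a stronger inhibitor of growth, a higher number a weaker inhibitor of growth. Compound 3 stands at the lowest number of the three, and its gaps to compound 1 and to compound 2 both lie beyond the usual scatter of repeated measurements, so compound 3 is the strongest growth inhibitor in this set.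

Compound 4 `CC[C@@H]1C(=O)N(C)c2cnc(-n3ccc4ccccc43)nc2N1C1CCCC1` differs from compound 3 in one place: hydrogen in place of isopropylcarbamoyl on an aromatic carbon. Within the data shown here, no two measured compounds differ in only one place, so there is no measured single-change step to compare against; the expectation rests on compound 3 alone and on the size of the group removed, six heavy atoms carrying one hydrogen-bond donor and one acceptor. Losing that much of the molecule is expected to weaken growth inhibition, and the step from compound 3 to compound 4 is estimated at a 3.0-fold higher number from compound 3 to compound 4 (0.48 log units; beyond the scatter), beyond the scatter. Compound 4 is therefore expected to give about 5500 nM in this assay, within a range of 1800 nM to 17000 nM.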

Compound 4, concentration for 50% growth inhibition: 28300 nM
Beside the measured number, compound 4's estimate is 5.1-fold (0.71 log units) below it; the whole stated range lies below it.
By their numbers in this assay, from the lowest: compound 3; then compound 1; then compounds 2 and 4 (each within the scatter of the next).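

In this assay, replacing isopropylcarbamoyl with hydrogen on this aromatic carbon gives a 15-fold higher number from compound 3 to compound 4 (1.19 log units; beyond the scatter), a large step and the first in this set that isolates a single change. The earlier compounds shown here differ from one another in more than one place, so they could not tie growth inhibition to any one group, whereas this pair shows that the activity is highly sensitive to the change at this position. Nothing available here explains why the loss is so large.

Still open, on these data alone, is which part of the group carries the effect: a plain carbamoyl, a carboxylic acid or an amine on the same carbon would help to separate the roles of its parts. Also open, as far as these compounds go, is whether a longer chain on the amide nitrogen would retain, improve or weaken growth inhibition.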